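The source may report more compounds than this note shows. Statements on the series, on what has been measured and on what is new or still open speak of the compounds shown alone.

Compound 1, `CCOC(=O)N1CCN(/[N+]([O-])=N/Oc2cc(O/N=[N+](\[O-])N(C)C)c([N+](=O)[O-])cc2[N+](=O)[O-])CC1`: 1200 nM in a functional assay on HL-60 cells (Homo sapiens) for antiproliferative activity, read by MTT assay, with a stated time of 72 h; on this read-out lower numbers stand for stronger inhibition and higher numbers for weaker inhibition
Compound 2, `CN(C)/[N+]([O-])=N/Oc1cc(O/N=[N+](\[O-])N2CCN(c3ncccn3)CC2)c([N+](=O)[O-])cc1[N+](=O)[O-]`: 1200 nM in this assay
Compound 3, `CN(C)/[N+]([O-])=N/Oc1cc(O/N=[N+](\[O-])N2CCCCC2)c([N+](=O)[O-])cc1[N+](=O)[O-]`: 1700 nM in this assay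

Compound 3 stands at a number that the scatter does not separate from those of compound 1 or compound 2; the step of a 1.4-fold higher number from compound 1 to compound 3 (0.15 log units; within the scatter) lies within the scatter, as does no change at the digits printed from compound 1 to compound 2 (within the scatter). Compound 4, `CC1CCCCN1/[N+]([O-])=N/Oc1cc(O/N=[N+](\[O-])N(C)C)c([N+](=O)[O-])cc1[N+](=O)[O-]`, differs from compound 3 by methyl in place of hydrogen on a saturated ring carbon. Going by the values given here, no measured step touches a saturated ring carbon: the two known steps exchanged the whole group on the double-bonded nitrogen or the substituent on the ring amine, and both stayed within the scatter. The step to compound 4 is therefore expected to stay within the scatter as well, in no favoured direction: no change at the digits printed from compound 3 to compound 4 (within the scatter). Compound 4 is estimated at 1700 nM in this assay, with a range from 850 nM to 3400 nM.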

Compound 4, half-maximal inhibitory concentration: 1500 nM
The estimate for compound 4 lay 1.1-fold (0.05 log units) above the measured number; measured number inside the range.
By their numbers in this assay, from the lowest: compounds 1, 2, 4 and 3 (each within the scatter of the next).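

In this assay, going by these compounds alone, the step of methyl in place of hydrogen on a saturated ring carbon, next to the ring nitrogen, gives a 1.1-fold lower number from compound 3 to compound 4 (0.05 log units; within the scatter) and is the first measured change at this ring carbon. Exchanging the whole group on the double-bonded nitrogen, 2-methylpiperidin-1-yl in place of 4-(ethoxycarbonyl)piperazin-1-yl, likewise gives a 1.3-fold higher number from compound 1 to compound 4 (0.10 log units; within the scatter) and so adds no separation among these compounds. Nothing available explains these results. As far as these compounds go, whether ethyl, a hydroxyl or an amine on this same ring carbon would also stay within the scatter remains open. So does the effect of methyl on the other ring carbons.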